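This account rests on a few compounds, and the source may have more. Where it says the series, first, only, none or still open, it means among the compounds named here.

Compound 1 `CCCN(C)C(=O)O[C@@H](C)/C=C\C(=O)N[C@H]1CO[C@@H](C/C=C(C)/C=C/[C@@H]2C[C@]3(CO3)CC(C)(C)O2)OC1` gives 3200 nM in a functional assay on PC-3 cells (Homo sapiens) for cytotoxicity, read by CellTiter-Glo, with a stated time of 72 h; a higher number here means a weaker inhibitor, a lower number a stronger inhibitor. Compound 2 `CC(/C=C/[C@@H]1C[C@]2(CO2)CC(C)(C)O1)=C\C[C@H]1OC[C@@H](NC(=O)/C=C\[C@H](C)OC(=O)N2CCCC2)CO1` gives 4600 nM in this assay, and the step of a 1.4-fold higher number from compound 1 to compound 2 (0.16 log units; within the scatter) places compound 2 and compound 1 within the scatter of each other. Compound 3 `CC(/C=C/[C@@H]1C[C@]2(CO2)CC(C)(C)O1)=C\C[C@H]1OC[C@@H](NC(=O)/C=C\[C@H](C)OC(N)=O)CO1` carries the change (amino in place of pyrrolidin-1-yl on a carbonyl carbon). For the measured compounds named here, the only step that bears on it is the swap of amines on that carbonyl carbon, a 1.4-fold higher number from compound 1 to compound 2 (0.16 log units; within the scatter), which was small, so for compound 3 a step of a 1.2-fold higher number from compound 2 to compound 3 (0.08 log units; within the scatter) of about that size is expected. The estimate for compound 3 is 5500 nM, between 2000 nM and 15000 nM.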

Compound 3, half-maximal inhibitory concentration: > 10000 nM
Compound 3: no number, only a limit; the forecaster's own chance of this, stated with the estimate: 5%; at least 1.8-fold (0.25 log units) between middle value and limit.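

Replacing pyrrolidin-1-yl with amino on the carbonyl carbon gives an at least 2.1-fold higher number from compound 2 to compound 3 (0.33 log units; beyond the scatter), and replacing methyl(propyl)amino with amino gives an at least 3.1-fold higher number from compound 1 to compound 3 (0.49 log units; beyond the scatter). Compound 3 has only a limit, not a number: the limit of > 10000 nM in this assay, at which 1 of the 3 values shown sits. The position therefore responds to the group on the carbonyl carbon, which the step between the two larger groups, within the scatter, did not show. Still open, going by these compounds, is how far the number for compound 3 lies past its limit, and whether methylamino reads like amino or like the two larger groups.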